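This account rests on a few compounds, and the source may have more. Where it says the series, first, only, none or still open, it means among the compounds named here.

Measured so far in a functional assay on K562 cells (Homo sapiens) for cytotoxicity, read by MTT assay, with a stated time of 24 h; on this read-out higher numbers stand for weaker inhibition and lower numbers for stronger inhibition:

Compound 1 `COc1ccc(/C=C2\CN(C)C/C(=C\c3ccccc3F)C2=O)cc1OC` gives 18000 nM in this test
Compound 2 `COc1cc(/C=C2\CN(C)C/C(=C\c3ccc(F)cc3)C2=O)cc(OC)c1` gives 11300 nM in this test

These two values lie within the usual scatter of each other, so compound 2 holds no clear rank against compound 1 and the pair shares one range. The next compound to be read is compound 3 `COc1cc(/C=C2\CN(C)C/C(=C\c3cccc([N+](=O)[O-])c3)C2=O)cc(OC)c1`, which is compared here with compound 2. The change is 3-nitrophenyl in place of 4-fluorophenyl on a double-bonded chain carbon bound to a double-bonded ring carbon and, in words, it puts 3-nitrophenyl in place of 4-fluorophenyl on a double-bonded chain carbon bound to a double-bonded ring carbon.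

For the measured compounds named here, no measured pair isolates a single change, so nothing sizes this swap directly. Going by the values given here, the only guide is that compound 1 at 18000 nM and compound 2 at 11300 nM stay close although they differ in more than one place. The step expected in this assay is a 1.4-fold lower number from compound 2 to compound 3 (0.15 log units; within the scatter) and it is expected to lean slightly toward lower numbers without going beyond the scatter. For compound 3 the estimated value is 8000 nM with an expected range from 2500 nM to 20000 nM on this read-out.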

Compound 3, half-maximal inhibitory concentration: 4420 nM
Compound 3: middle estimate off by 1.8-fold (0.26 log units), on the high side; the range from low to high includes it.
By their numbers in this assay, from the lowest: compound 3; then compounds 2 and 1 (each within the scatter of the next).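

In this assay, for the compounds shown here, putting 3-nitrophenyl in place of 4-fluorophenyl on a double-bonded chain carbon bound to a double-bonded ring carbon gives a 2.6-fold lower number from compound 2 to compound 3 (0.41 log units; beyond the scatter), the first step here that isolates a single change. It shows that the number in this test responds to the group at this place while the rest of the molecule stays the same, although the step is only modest and rests on this one pair. No independent measurement bears on why the number moves with this swap.

The swap changes both the group on the phenyl ring and where that group stands, so this one pair cannot tell which of the two matters, and 3-fluorophenyl or 4-nitrophenyl at the same place would be needed to separate them. On these data alone, it also remains open whether the lower number is particular to the nitro group or would also appear with a different group on the phenyl ring, such as an amine or a carboxylic acid.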